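Swapping the Aryl Group on the Carbonyl of a Shared Core

The source may report more compounds than this note shows. Statements on the series, on what has been measured and on what is new or still open speak of the compounds shown alone.

Of the compounds shown here, three with a shared core have been measured in a functional assay (trachea) with Rattus norvegicus as the target; a higher number here means a more potent compound, by a factor of ten per unit of this negative logarithm, a lower number a less potent compound. Compound 1 `COc1ccc(C(=O)c2ccc3c(c2)C(n2ccccc2=O)=CC(C)(C)O3)cc1` gives 5.72, compound 2 `CC1(C)C=C(n2ccccc2=O)c2cc(C(=O)c3ccco3)ccc2O1` gives 5.92, and compound 3 `CC1(C)C=C(n2ccccc2=O)c2cc(C(=O)c3ccc(O)cc3)ccc2O1` gives 5.87. Of the three numbers shown, that of compound 3 is the second highest; its nearest neighbour is compound 2 and its furthest is compound 1, and both gaps lie within the scatter. Compound 4 `CC1(C)C=C(n2ccccc2=O)c2cc(C(=O)c3ccccc3C(F)(F)F)ccc2O1` has not yet been measured. It differs from compound 3 in one place: 2-(trifluoromethyl)phenyl in place of 4-hydroxyphenyl on a carbonyl carbon. Going by the values given here, two measured steps bear on this change, since each also exchanges the group on the carbonyl carbon: a number 0.20 log units higher from compound 1 to compound 2 (within the scatter) and a number 0.05 log units lower from compound 2 to compound 3 (within the scatter). Neither moved the number beyond the scatter, and the remaining step, a number 0.15 log units higher from compound 1 to compound 3 (within the scatter), was likewise small. Among the compounds with values here, no step of this kind points to a shift beyond the scatter in this assay, so the expected step is a number 0.02 log units lower from compound 3 to compound 4 (within the scatter). For compound 4 the estimate in this assay is 5.85, with a range from 5.4 to 6.3.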

Compound 4, logarithm of the reciprocal of the active concentration, log(1/C): 5.78
Estimate against measurement, compound 4: 0.07 log units above, and the stated range covers the measured number.
By their numbers in this assay, from the lowest: compounds 1, 4, 3 and 2 (each within the scatter of the next).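

In this assay, 2-(trifluoromethyl)phenyl on the carbonyl carbon, a group without hydrogen-bond donors or acceptors, takes the place of 4-hydroxyphenyl, which has both, and the step is small: a number 0.09 log units lower from compound 3 to compound 4 (within the scatter). The same holds against the other two groups, with a number 0.14 log units lower from compound 2 to compound 4 (within the scatter) and a number 0.06 log units higher from compound 1 to compound 4 (within the scatter), so all four groups shown at this place give numbers within the scatter of one another, and no compound goes against this. Nothing measured here explains why the number stays so steady.

From the compounds shown here alone, all four groups on the carbonyl carbon are aromatic rings, so it remains open how an amine, a carboxylic acid or a longer alkyl chain at this place would read. Also open, going by these compounds, is whether changes elsewhere on the shared core would move the number further.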